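Pyridin-3-yl for pyrimidin-5-yl at the sulfonylpyrrole series

A few compounds are considered here, and "the series" means these few. Any claim that something is new, unique, unknown or untested is made for them only; others in the source may bear on it.

Compound 3 `CNCc1cc(-c2cncnc2)n(S(=O)(=O)c2ccccc2)c1` has no single number in a functional assay on the whole organism (strain Jcl:SD) for inhibition, with Rattus norvegicus as the target, with stated times of 3 min and 3 h, at a dose of 1 mg/kg by the intravenous route; on this read-out lower numbers stand for less inhibition and higher numbers for more inhibition at the one dose given (going by the name of the read-out): compound 3 gives "not determined" (no result reported), so it stands nowhere on the scale and compound 4 cannot be placed against it by a step. Compound 4 `CNCc1cc(-c2cccnc2)n(S(=O)(=O)c2ccccc2)c1` differs from compound 3 by pyridin-3-yl in place of pyrimidin-5-yl on an aromatic carbon.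

Going by the values given here, the only measured step in this assay is that from compound 1 `CNCc1cc(-c2ccccc2)n(S(=O)(=O)c2ccc(C)cc2)c1` to compound 2 `CNCc1cc(-c2ccccc2)n(S(=O)(=O)c2ccccc2)c1`, where compound 1 gives 66% and compound 2 gives 96%, a change of a number 30 percentage points higher from compound 1 to compound 2 (beyond the scatter). That step touches the sulfonyl-bearing ring, not the group exchanged between compound 3 and compound 4, so it does not bear on the present change; it shows only that the series can reach high inhibition at this dose. For compound 4 the expectation is therefore anchored mainly on compound 2, which shares the same sulfonyl-bearing ring and the same (methylamino)methyl group, with wide uncertainty for the six-membered ring with 1 hetero atom. Compound 4 is estimated at 80%, with a range from 45% to 98%.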

Compound 4, a percentage reported as inhibition, in the whole organism at one dose (the size of the read-out at that dose, not a potency) in the Rattus norvegicus assay: 4%
For compound 4 the middle estimate is 76 percentage points above the measured one; the measured number lies below the stated range.
By their numbers in the Rattus norvegicus assay, from the lowest: compound 4; then compound 1; then compound 2.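

In the Rattus norvegicus assay, the six-membered ring on the aromatic carbon next to the ring nitrogen proves decisive, which the earlier change on the sulfonyl-bearing ring could not show: a number 92 percentage points lower from compound 2 to compound 4 (beyond the scatter). Phenyl and pyridin-3-yl therefore cannot be treated as interchangeable at this position in the shared core. In a physicochemical assay for lipophilicity, read by HPLC, at pH 7.4 (a higher number here means a more lipophilic compound, a lower number a more polar compound), compound 3 gives -0.4 and compound 4 gives 0.08, but these distribution coefficients do not bear on the loss of inhibition, as compound 2 has no such value here.

Steps from compound 3 in the Rattus norvegicus assay cannot be read, so the effect of pyridin-3-yl in place of pyrimidin-5-yl on inhibition remains unknown. Also open, as far as these compounds go, is whether a methoxy group on the pyridin-3-yl ring would restore inhibition in the Rattus norvegicus assay.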